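Return to an aryl group on the pyrazole-type nitrogen

The source may report more compounds than this note shows. Statements on the series, on what has been measured and on what is new or still open speak of the compounds shown alone.

Compound 1 `O=C(O)c1cc(-c2ccc(-c3ccc(Cl)cc3Cl)cc2)n(-c2ccc(Cl)cc2Cl)n1` gives 11900 nM in an assay on isolated protein for inhibition of methionine--tRNA ligase, cytoplasmic (Homo sapiens); a higher number here means a weaker inhibitor, a lower number a stronger inhibitor. Compound 2 `O=C(O)c1cc(-c2ccc(-c3ccc(Cl)cc3Cl)cc2)n(Cc2cccnc2)n1` reaches only a limit of the assay in this assay, > 100000 nM. That is the limit of > 100000 nM in this assay, at which 1 of the 2 values shown sits. Going by the values given here, the one measured step, an at least 8.4-fold higher number from compound 1 to compound 2 (0.92 log units; beyond the scatter), bears directly on the change at hand, since it exchanged a six-membered aromatic ring of carbon only on the aromatic nitrogen for (pyridin-3-yl)methyl. Compound 3 `COc1ccc(-n2nc(C(=O)O)cc2-c2ccc(-c3ccc(Cl)cc3Cl)cc2)cc1` carries 4-methoxyphenyl in place of (pyridin-3-yl)methyl on an aromatic nitrogen. This puts a six-membered aromatic ring of carbon only back on the aromatic nitrogen, as in compound 1, so a step back in the direction of compound 1 is expected, though compound 1 itself is weak in this assay and the new ring carries a methoxy group rather than two chlorines. For compound 3 a step of an at least 4.0-fold lower number from compound 2 to compound 3 (0.60 log units; beyond the scatter) is expected. Compound 3 is estimated at 25000 nM, in the range 7000 nM to 90000 nM.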

Compound 3, half-maximal inhibitory concentration: > 100000 nM
Compound 3 ended at the assay's limit; the forecaster's own chance of this, stated with the estimate: 30%; middle value at least 4.0-fold (0.60 log units) from the limit.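

Putting an aryl group back on the aromatic nitrogen does not by itself retain measurable inhibition in this assay: 4-methoxyphenyl in place of 2,4-dichlorophenyl gives an at least 8.4-fold higher number from compound 1 to compound 3 (0.92 log units; beyond the scatter). Among the three groups shown at this position, only the 2,4-dichlorophenyl of compound 1 gives a readable value, so a six-membered aromatic ring of carbon only is not sufficient here. Compound 2 and compound 3 both stand at a limit rather than at a number, so the step between them cannot be read, and the series is gathering at that limit: the limit of > 100000 nM in this assay, at which 2 of the 3 values shown sit.

On these data alone, whether the loss follows from the methoxy group or from the absence of the chlorines remains open. A 4-chlorophenyl or a 2-chlorophenyl on the same nitrogen would separate the contribution of each chlorine.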